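The source may hold more compounds than are shown below. What is called first, only, known or untested is meant among the compounds shown, and "the series" means these compounds.

Measured compounds:
Compound 1 `CCOC(=O)c1cnc(-c2ccccc2OCC)[nH]c1=O` gives 2 mg/kg in a functional assay on the whole organism (strain Sprague-Dawley) for inhibition, with Rattus norvegicus as the target, with a stated time of 10 min; a higher number here means that more compound is needed for the effect, a lower number that less compound is needed.
Compound 2 `CCOC(=O)c1cnc(-c2ccccc2SCC)[nH]c1=O` reaches only a limit of the assay, > 5 mg/kg.

Going by the values given here, compound 1 holds the only real number in this set. Among the compounds with values here, the single measured step, an at least 2.5-fold higher number from compound 1 to compound 2 (0.39 log units; beyond the scatter), comes from swapping the ethoxy group for ethylsulfanyl on the aromatic ring. The sentence above about compound 2 describes a limit, not a number, so the exact size of that step is not known.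

Compound 3 `CCOC(=O)c1cnc(-c2cc(S(=O)(=O)N(C)C(C)C)ccc2OCC)[nH]c1=O` differs from compound 1 by isopropyl(methyl)sulfamoyl in place of hydrogen on an aromatic carbon. Within the data shown here, the ethoxy group of compound 1 stays in place in compound 3, so the measured step does not directly bear on this change; no measured compound shows what adding such a group does here. With no guidance from the data, a step within the scatter is expected in this assay. Compound 3 is therefore estimated at 2.5 mg/kg, with a range from 1 mg/kg to 7 mg/kg. This estimate means a step of a 1.3-fold higher number from compound 1 to compound 3 (0.10 log units; within the scatter), expected to be within the usual scatter.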

Compound 3, dose for 50% inhibition: > 10 mg/kg
Compound 3 gave a limit, no number; the forecaster's own chance of this, stated with the estimate: 30%; middle value at least 4.0-fold (0.60 log units) from the limit.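

In this assay, placing isopropyl(methyl)sulfamoyl on the aromatic carbon para to the ethoxy group gives an at least 5.0-fold higher number from compound 1 to compound 3 (0.69 log units; beyond the scatter). Going by these compounds alone, the earlier step concerned only the ethoxy group itself, so this is the first sign that the result also depends on a second place on this ring, where hydrogen does better than this group. Compound 3 gives only a limit, so the full size of the step stays unknown: the limit of > 10 mg/kg in this assay, at which 1 of the 3 values shown sits.

From the compounds shown here alone, a single large group says little about this position in general, and it remains open whether a small methyl group, an amine or a carboxylic acid would be tolerated there. Going by these compounds, it is also open whether a shorter sulfamoyl group without the isopropyl and methyl substituents would give the same result.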